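Sulfonyl group exchange, compound 3 to compound 4

A few compounds are considered here, and "the series" means these few. Any claim that something is new, unique, unknown or untested is made for them only; others in the source may bear on it.

Three measured compounds share one core and differ only in the group on the sulfonyl sulfur: compound 1 `Cc1ccc2[nH]c(C(=O)N[C@H]3CN(S(=O)(=O)c4ccccc4)C[C@@H]3C(=O)NCCN(C)C)cc2c1`, compound 2 `Cc1ccc2[nH]c(C(=O)N[C@H]3CN(S(=O)(=O)c4ccnc(C)c4)C[C@@H]3C(=O)NCCN(C)C)cc2c1` and compound 3 `Cc1ccc2[nH]c(C(=O)N[C@H]3CN(S(=O)(=O)c4cn(C)nc4C)C[C@@H]3C(=O)NCCN(C)C)cc2c1`. In an ADME assay on the whole organism (Rattus norvegicus, strain Harlan-Han Wistar) for pharmacokinetics (a higher number here means faster removal of the compound, a lower number slower removal), compound 1 gives 79 mL/min/kg, compound 2 gives 66 mL/min/kg and compound 3 gives 45 mL/min/kg. Compound 3 stands within the scatter of both others, as shown by a 1.8-fold lower number from compound 1 to compound 3 (0.24 log units; within the scatter) and a 1.5-fold lower number from compound 2 to compound 3 (0.17 log units; within the scatter).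

Compound 4 `Cc1ccc2[nH]c(C(=O)N[C@H]3CN(S(=O)(=O)C4CCOCC4)C[C@@H]3C(=O)NCCN(C)C)cc2c1` keeps the shared core and carries oxan-4-yl in place of 1,3-dimethyl-1H-pyrazol-4-yl on a sulfonyl sulfur. All three measured steps bear on this change, since each exchanges the group at the same place. The third is a 1.2-fold lower number from compound 1 to compound 2 (0.08 log units; within the scatter). Among the measured compounds shown here, none of the three goes beyond the scatter, but all of them involve aromatic rings, so the data contain no direct precedent for a non-aromatic ring here. No step beyond the scatter is therefore expected in this assay, and the data support no direction. The estimated step is a 1.2-fold higher number from compound 3 to compound 4 (0.09 log units; within the scatter). The expected value for compound 4 is 55 mL/min/kg, with an estimated range of 30 mL/min/kg to 95 mL/min/kg.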

Compound 4, clearance: 104 mL/min/kg
For compound 4 the middle estimate is 1.9-fold (0.28 log units) below the measured one; the measured number lies above the stated range.
By their numbers in this assay, from the lowest: compounds 3, 2, 1 and 4 (each within the scatter of the next, the first and the last beyond it).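

In this assay the group on the sulfonyl sulfur gives its first step beyond the scatter at this position (a 2.3-fold higher number from compound 3 to compound 4 (0.36 log units; beyond the scatter)), a modest one, so exchanging this group can move the read-out. The oxan-4-yl group of compound 4 stays within the scatter of the two other aromatic groups (a 1.6-fold higher number from compound 2 to compound 4 (0.20 log units; within the scatter); a 1.3-fold higher number from compound 1 to compound 4 (0.12 log units; within the scatter)), so compounds 1 and 2 go against any pattern that separates the non-aromatic ring from aromatic rings as a class, and the only separation shown is from 1,3-dimethyl-1H-pyrazol-4-yl. No measurement at hand accounts for this step.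

Open, on these data alone, is whether the step belongs to the ring oxygen of oxan-4-yl, which a comparison with cyclohexyl, an all-carbon ring of the same size, would address. Also open is how this assay responds on this sulfonyl sulfur to an open chain such as n-butyl, or to a non-aromatic ring carrying an amine or a carboxylic acid, since every group shown here is an unsubstituted or methyl-substituted ring.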